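From methoxy to ethoxy on a shared core

The compounds below may be only part of what the source reports. "The series", "measured", "known", "first", "only" and "open" are said of these compounds alone.

Three related compounds have been tested so far in a functional assay on HeLa cells (Homo sapiens) for cytotoxicity, read by XTT assay, with a stated time of 24 h; a lower number here means a stronger inhibitor, a higher number a weaker inhibitor. Compound 1 `COc1c(C)cc(Cl)c2c1C(=O)C=CC2=O` gives 41500 nM, compound 2 `CC(=O)Oc1cc(C)c(Cl)c2c1C(=O)C=CC2=O` gives 26200 nM, and compound 3 `CC(=O)Oc1cc(OC(C)=O)c2c(OC(C)=O)c(C)cc(Cl)c2c1OC(C)=O` gives 27900 nM. Repeated measurements of this kind naturally vary, and compound 1 stands within that scatter of both of the others. These numbers therefore set no order among the three compounds.

The next compound to be tested is compound 4 `CCOc1c(C)cc(Cl)c2c1C(=O)C=CC2=O`. It differs from compound 1 at one place: methyl in place of hydrogen on a saturated chain carbon bound to an oxygen on an aromatic ring. Put simply, the methoxy of compound 1 becomes the ethoxy of compound 4.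

Among the measured compounds shown here, no pair of measured compounds tests this change directly, so there is no earlier step to borrow. The expectation rests only on the general level of the series, with compound 1 at 41500 nM as the closest reference. No shift beyond the scatter is expected, and no direction is favoured with any confidence. The estimated change is a 1.2-fold lower number from compound 1 to compound 4 (0.06 log units; within the scatter), a step expected to be lost in the scatter. The expected value for compound 4 is 36000 nM, with an estimated range from 18000 nM to 70000 nM.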

Compound 4, half-maximal inhibitory concentration: 33200 nM
The estimate for compound 4 lay 1.1-fold (0.04 log units) above the measured number; the measured number falls inside the stated range.
By their numbers in this assay, from the lowest: compounds 2, 3, 4 and 1 (each within the scatter of the next).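

Among the compounds shown here, this is the first direct reading of this change at this place: swapping methoxy for ethoxy, a methyl in place of hydrogen on a saturated chain carbon bound to an oxygen on an aromatic ring, gives a 1.3-fold lower number from compound 1 to compound 4 (0.10 log units; within the scatter) in this assay. Compound 1 and compound 4 therefore cannot be told apart here, and the one extra carbon on this chain does not move the reading past the normal spread of repeat measurements, so this single step gives no sign that the assay responds to this change. No measurement on these compounds offers an explanation for this result.

From the compounds shown here alone, with only methoxy and ethoxy to compare at this place, it remains open whether a longer chain such as butyl would also stay within the scatter, or whether a chain ending in an amine or a carboxylic acid would shift the number clearly. Going by these compounds, it is also open whether the same methyl-for-hydrogen swap would read the same way on a different part of the shared core, since this one pair speaks only for this place.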